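Trifluoromethyl Moved Along the Aromatic Ring

The source may report more compounds than this note shows. Statements on the series, on what has been measured and on what is new or still open speak of the compounds shown alone.

Measured compounds:
Compound 1, `O=C1C=CCC(/C=C/c2ccccc2)N1`, gives > 1250 uM.
Compound 2, `O=C1C=CCC(/C=C/c2ccccc2C(F)(F)F)N1`, gives 123 uM.

Both numbers come from a functional assay on 786-0 cells (Homo sapiens) for inhibition, read by sulforhodamine B assay, with a stated time of 48 h; on this read-out higher numbers stand for weaker inhibition of growth and lower numbers for stronger inhibition of growth. For compound 1 the figure is not a measured number but a limit: compound 1 sits at the limit of > 1250 uM in this assay, at which 1 of the 2 values shown sits. Compound 2, which carries a trifluoromethyl on an aromatic carbon of the same ring, gives 123 uM in this assay, so the change from compound 1 to compound 2 is an at least 10-fold lower number from compound 1 to compound 2 (1.00 log units; beyond the scatter).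

Compound 3, `O=C1C=CCC(/C=C/c2ccc(C(F)(F)F)cc2)N1`, has not yet been measured in this assay. It differs from compound 1 as follows: trifluoromethyl in place of hydrogen on an aromatic carbon. Among the compounds with values here, the only measured step that bears on this change is the one from compound 1 to compound 2, which was at least modest in the direction of stronger growth inhibition. A step of similar size and direction is therefore expected here, although the trifluoromethyl in compound 3 sits on another aromatic carbon, so the size is uncertain. Compound 3 is expected to give about 150 uM in this assay, between 40 uM and 600 uM, which would mean an estimated step of an at least 8.3-fold lower number from compound 1 to compound 3 (0.92 log units; beyond the scatter).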

Compound 3, concentration for growth inhibition (reported as GI): 128 uM
Beside the measured number, compound 3's estimate is 1.2-fold (0.07 log units) above it; measured number inside the range.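

With the trifluoromethyl para to a group of 9 heavy atoms, the data show an at least 9.7-fold lower number from compound 1 to compound 3 (0.98 log units; beyond the scatter), so the stronger growth inhibition seen with compound 2 is not confined to a single aromatic carbon of the ring. In this assay compound 2 gives 123 uM and compound 3 gives 128 uM; these values lie within the usual scatter of each other, so the two placements of the trifluoromethyl cannot be told apart here. The true size of each step from compound 1 remains unknown, since compound 1 is the only one of the three compounds shown that is held at a limit and not at a measured number: the limit of > 1250 uM in this assay, at which 1 of the 3 values shown sits.

The compounds shown leave open whether the trifluoromethyl itself matters or whether another group on the same aromatic carbon, such as a methyl, a methoxy, an amine or a carboxylic acid, would give a similar number. They also leave open what a trifluoromethyl would give on the other aromatic carbons of the ring, and whether a second such group would add to the step.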